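Swapping the aryl group on a four-membered lactam core

A few compounds are considered here, and "the series" means these few. Any claim that something is new, unique, unknown or untested is made for them only; others in the source may bear on it.

Measured so far:
compound 1 `COc1cc(N2C(=O)[C@@H](Oc3ccccc3)[C@H]2c2cccc3ccccc23)cc(OC)c1OC` — 53000 nM
compound 2 `COc1cc(N2C(=O)[C@@H](Oc3ccccc3)[C@H]2c2ccc(SC)cc2)cc(OC)c1OC` — 7700 nM

Both compounds were tested in a functional assay on MCF7 cells (Homo sapiens) for antiproliferative activity, read by MTT assay, with stated times of 24 h and 72 h; a lower number here means a stronger inhibitor, a higher number a weaker inhibitor. Compound 2 gives the lowest of the two numbers; its nearest neighbour is compound 1, and the step of a 6.9-fold lower number from compound 1 to compound 2 (0.84 log units; beyond the scatter) lies beyond the scatter, so compound 2 is the stronger of the pair.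

Compound 3 `COc1cc([N+](=O)[O-])c([C@@H]2[C@H](Oc3ccccc3)C(=O)N2c2cc(OC)c(OC)c(OC)c2)cc1O` has not yet been measured. It differs from compound 2 by a group of 12 heavy atoms (7 carbon, 1 nitrogen, 4 oxygen; one six-membered aromatic ring of carbon only) in place of a group of 8 heavy atoms (7 carbon, 1 sulfur; one six-membered aromatic ring of carbon only), on a saturated ring carbon. Among the compounds with values here, the only measured step that touches this same saturated ring carbon is the one from compound 1 to compound 2, which was modest in size. Within the data shown here, that step concerns a different exchange, so it gives only a loose guide to the direction, and no measured step concerns the entering group itself. Compound 3 is therefore estimated at 1500 nM, within a wide range from 150 nM to 15000 nM, which would mean an expected step of a 5.1-fold lower number from compound 2 to compound 3 (0.71 log units; beyond the scatter).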

Compound 3, half-maximal inhibitory concentration: 59000 nM
For compound 3 the middle estimate is 39-fold (1.59 log units) below the measured one; the whole stated range lies below it.
By their numbers in this assay, from the lowest: compound 2; then compounds 1 and 3 (each within the scatter of the next).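

At the saturated ring carbon of the shared core, exchanging the 4-(methylsulfanyl)phenyl for the group in compound 3, which also has one six-membered aromatic ring, gives a 7.7-fold higher number from compound 2 to compound 3 (0.88 log units; beyond the scatter) in this assay. Keeping a single aromatic ring here is therefore not enough to hold the lower number of compound 2, and what the ring carries matters. The naphthalen-1-yl and the group in compound 3 differ greatly in shape, yet a 1.1-fold higher number from compound 1 to compound 3 (0.05 log units; within the scatter) leaves them indistinguishable in this assay, and no measured evidence accounts for either result.

Compound 3 changes several things on its ring at once, so these compounds cannot show which of its groups raises the number. They also leave open whether the sulfur matters, and how a phenyl carrying an amine or a methoxy group in place of the methylsulfanyl would compare.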